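Nitro in Place of Chloro on the Aromatic Ring

The compounds below may be only part of what the source reports. "The series", "measured", "known", "first", "only" and "open" are said of these compounds alone.

Among the compounds with values here, compound 3 `CC1=C(/C=C/C(=O)/C=C/c2ccccc2Cl)C(C)(C)CCC1` gives 11300 nM in a functional assay on PC-3 cells (Homo sapiens) for cytotoxicity, read by sulforhodamine B assay, with a stated time of 48 h (a lower number here means a stronger inhibitor, a higher number a weaker inhibitor), the highest of the three numbers so far; compound 1 `CC1=C(/C=C/C(=O)/C=C/c2ccc(Cl)cc2)C(C)(C)CCC1` sits nearest with 9500 nM, and compound 2 `CC1=C(/C=C/C(=O)/C=C/c2ccc(F)cc2)C(C)(C)CCC1` furthest with 8200 nM, both within the scatter of compound 3. Compound 4 `CC1=C(/C=C/C(=O)/C=C/c2ccccc2[N+](=O)[O-])C(C)(C)CCC1` differs from compound 3 by nitro in place of chloro on an aromatic carbon. Within the data shown here, no measured step exchanges a halogen for a nitro group; the steps that bear on it are a 1.2-fold lower number from compound 1 to compound 2 (0.06 log units; within the scatter), a 1.2-fold higher number from compound 1 to compound 3 (0.08 log units; within the scatter) and a 1.4-fold higher number from compound 2 to compound 3 (0.14 log units; within the scatter), all within the scatter. Changing the substituent or its place on the aromatic ring has so far moved this assay only within the scatter, so compound 4 is expected to shift by no more than a 1.0-fold lower number from compound 3 to compound 4 (0.01 log units; within the scatter). The estimate for compound 4 is 11000 nM, ranging from 5000 nM to 25000 nM.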

Compound 4, half-maximal inhibitory concentration: 9500 nM
For compound 4 the middle estimate is 1.2-fold (0.06 log units) above the measured one, and the stated range covers the measured number.
By their numbers in this assay, from the lowest: compounds 2, 1, 4 and 3 (each within the scatter of the next).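

In this assay, nitro in place of chloro, on an aromatic carbon ortho to a large group, gives a small step (a 1.2-fold lower number from compound 3 to compound 4 (0.08 log units; within the scatter)). Thus a group of three heavy atoms with two hydrogen-bond acceptors can replace a single chlorine here with the number staying within the scatter, something the halogen compounds alone could not show. No supporting measurement bears on this result. The compounds shown leave open whether an amine or a carboxylic acid on this aromatic carbon would also stay within the scatter, and whether changing the shared core would move the number beyond it.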